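The source may hold more compounds than are shown below. What is called first, only, known or untested is meant among the compounds shown, and "the series" means these compounds.

Of the compounds shown here, three built on one shared core have been tested in a functional assay on HT-29 cells (Homo sapiens) for antiproliferative activity, read by sulforhodamine B assay, with a stated time of 48 h; on this read-out higher numbers stand for weaker inhibition and lower numbers for stronger inhibition. Compound 1 `CCC(=O)Nc1ccc(S(=O)(=O)Oc2ccccc2C(C)C)cc1` gives 7400 nM, compound 2 `CCCCCC(=O)Nc1ccc(S(=O)(=O)Oc2ccccc2C(C)C)cc1` gives 6400 nM, and compound 3 `CC(C)c1ccccc1OS(=O)(=O)c1ccc(NC(=O)CCCl)cc1` gives 16000 nM, the highest of the three numbers. The steps of a 2.2-fold higher number from compound 1 to compound 3 (0.33 log units; beyond the scatter) and a 2.5-fold higher number from compound 2 to compound 3 (0.40 log units; beyond the scatter) are both beyond the scatter, whereas a 1.2-fold lower number from compound 1 to compound 2 (0.06 log units; within the scatter) is within it. Compound 4 `CCCCCNC(=O)Nc1ccc(S(=O)(=O)Oc2ccccc2C(C)C)cc1` differs from compound 3 by pentylamino in place of 2-chloroethyl on a carbonyl carbon, giving a pentylcarbamoyl group. Going by the values given here, the chloro group leaves again, so the two modest steps bear on this change, while no measured pair shows a pentylcarbamoyl group. A return toward the numbers of compound 1 and compound 2 is therefore expected, with wide uncertainty. The step of a 2.3-fold lower number from compound 3 to compound 4 (0.36 log units; beyond the scatter) is the expected outcome. Compound 4 is expected to give 7000 nM, in the range 2500 nM to 20000 nM.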

Compound 4, half-maximal inhibitory concentration: 4900 nM
Compound 4: middle estimate off by 1.4-fold (0.15 log units), on the high side, within the range that was stated.
By their numbers in this assay, from the lowest: compounds 4, 2 and 1 (each within the scatter of the next); then compound 3.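

Pentylamino in place of 2-chloroethyl on this carbonyl carbon gives a 3.3-fold lower number from compound 3 to compound 4 (0.51 log units; beyond the scatter), a step beyond the scatter. Against the two compounds without chlorine, a 1.3-fold lower number from compound 2 to compound 4 (0.12 log units; within the scatter) and a 1.5-fold lower number from compound 1 to compound 4 (0.18 log units; within the scatter) are both within the scatter, so at this position pentylamino reads the same as pentyl or ethyl, and only compound 3 stands apart. Nothing available explains these differences. On these data alone, what a hydroxyl group in place of the chloro, or a longer chain or cyclohexyl ring on the pentylamino nitrogen, would do remains open.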